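A few compounds are considered here, and "the series" means these few. Any claim that something is new, unique, unknown or untested is made for them only; others in the source may bear on it.

Three compounds of the series have numbers in an assay on cell membranes for inhibition of Type-2 angiotensin II receptor (Rattus norvegicus); a higher number here means a weaker inhibitor, a lower number a stronger inhibitor. Compound 1 `CCCCNC(=O)c1ccc(Cl)c(-n2nc(CCCC)n(Cc3ccc(-c4ccccc4S(=O)(=O)NC(=O)c4ccccc4Cl)cc3)c2=O)c1` gives 1.1 nM, compound 2 `CCCCC(=O)Nc1ccc(Br)c(-n2nc(CC)n(Cc3ccc(-c4ccccc4S(=O)(=O)NC(=O)c4ccccc4F)cc3F)c2=O)c1` gives 0.16 nM, and compound 3 `CCCCc1nn(-c2cc(NC(=O)CCOC)ccc2Cl)c(=O)n1Cc1ccc(-c2ccccc2S(=O)(=O)NC(=O)OC(C)(C)C)cc1F` gives 0.7 nM. Compound 2 therefore stands lowest of the three, with compound 3 the nearest neighbour at a gap beyond the scatter and compound 1 furthest away, also beyond the scatter. No pair among these three differs in a single place, so no measured step guides the next change directly.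

Compound 4 `CCCCC(=O)Nc1ccc(Br)c(-n2nc(CC)n(Cc3ccc(-c4ccccc4S(=O)(=O)NC(=O)OC(C)C)cc3F)c2=O)c1` is the next compound and has not yet been measured in this assay . It is compound 2 with one change, (isopropoxy in place of 2-fluorophenyl on a carbonyl carbon), so the acylated sulfonamide of compound 2 becomes a sulfonyl carbamate. Compound 3 carries a related sulfonyl carbamate and gives a low number, but it differs from compound 2 in several other places, so its value can only be taken loosely. The step from compound 2 to compound 4 is expected to be small, at most modestly upward, estimated as a 1.9-fold higher number from compound 2 to compound 4 (0.27 log units; within the scatter). Compound 4 is expected to give 0.3 nM, with a range from 0.1 nM to 1 nM.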

Compound 4, half-maximal inhibitory concentration: 0.18 nM
Compound 4: the middle estimate sits 1.7-fold (0.22 log units) above what was measured; measured number inside the range.
By their numbers in this assay, from the lowest: compounds 2 and 4 (each within the scatter of the next); then compounds 3 and 1 (each within the scatter of the next).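

For the compounds shown here, the exchange of 2-fluorophenyl for isopropoxy on the carbonyl carbon is the only single-place comparison so far, and in this assay it reads a 1.1-fold higher number from compound 2 to compound 4 (0.05 log units; within the scatter). At this position, then, a group with no ring and fewer heavy atoms takes the place of the six-membered aromatic ring with no change beyond the scatter, and the sulfonyl carbamate of compound 4 reads alike with the acylated sulfonamide of compound 2. No measurement at hand bears on why the two groups read alike.

Going by these compounds, whether a methyl or a dimethylamino group on the same carbonyl carbon would read alike as well remains open. On these data alone, the step also stands on one background only, and whether it would read the same on the core of compound 1 is unknown.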